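A few compounds are considered here, and "the series" means these few. Any claim that something is new, unique, unknown or untested is made for them only; others in the source may bear on it.

In an assay on microsomes from liver for inhibition of 3-hydroxy-3-methylglutaryl-coenzyme A reductase (Rattus norvegicus), read by scintillation counting, with stated times of 0.5 h and 0.75 h (a higher number here means a weaker inhibitor, a lower number a stronger inhibitor), compound 1 `Cc1ccc(CNC(=O)c2nc(-c3ccc(F)cc3)n(CC[C@@H](O)C[C@@H](O)CC(=O)O)c2C2CC2)cc1` gives 1.7 nM. Among the measured compounds shown here, only one other compound has been measured alongside it: compound 2 `COc1ccc(CNC(=O)c2nc(-c3ccc(F)cc3)n(CC[C@@H](O)C[C@@H](O)CC(=O)O)c2C2CC2)cc1`, which in this assay gives 1.2 nM, so that compound 1 and compound 2 sit within the scatter of each other, the step being a 1.4-fold lower number from compound 1 to compound 2 (0.15 log units; within the scatter) for methoxy in place of methyl on an aromatic carbon.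

Compound 3 `O=C(O)C[C@H](O)C[C@H](O)CCn1c(-c2ccc(F)cc2)nc(C(=O)NCc2ccccc2)c1C1CC1` differs from compound 1 by hydrogen in place of methyl on an aromatic carbon. For the measured compounds named here, the one measured step that bears on this change is the exchange at the same aromatic carbon from compound 1 to compound 2, which stayed within the scatter. With a small group removed rather than exchanged, compound 3 is therefore expected to move little beyond the scatter, if anything toward a slightly higher number, a step of a 1.4-fold higher number from compound 1 to compound 3 (0.13 log units; within the scatter). Compound 3 is estimated at 2.3 nM, with a range from 1 nM to 5.5 nM.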

Compound 3, half-maximal inhibitory concentration in the 3-hydroxy-3-methylglutaryl-coenzyme A reductase assay: 1.4 nM
The estimate for compound 3 lay 1.6-fold (0.22 log units) above the measured number; measured number inside the range.
By their numbers in the 3-hydroxy-3-methylglutaryl-coenzyme A reductase assay, from the lowest: compounds 2, 3 and 1 (each within the scatter of the next).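

In the 3-hydroxy-3-methylglutaryl-coenzyme A reductase assay, the result adds a case where the substituent is removed altogether, not merely exchanged: a 1.2-fold lower number from compound 1 to compound 3 (0.08 log units; within the scatter), and a 1.2-fold higher number from compound 2 to compound 3 (0.07 log units; within the scatter), so methyl, methoxy and hydrogen on this aromatic carbon cannot be told apart. In a physicochemical assay for lipophilicity, using the shake flask method, at pH 7.4 (a lower number here means a more polar compound, a higher number a more lipophilic compound), compound 1 gives 0.45 and compound 3 gives 0.03. Hydrogen in place of methyl therefore separates the two compounds in lipophilicity, although it does not separate them in inhibition: the measured distribution coefficient of compound 1, 0.45, and of compound 3, 0.03, a number 0.42 log units lower (beyond the scatter)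

The compounds shown leave open whether a group of another kind on this carbon, such as an amine or a carboxylic acid, would also stay within the scatter. They also leave open whether a longer chain there would do the same.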